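Chloro for hydroxy on the aryl ketone of the shared core

The source may report more compounds than this note shows. Statements on the series, on what has been measured and on what is new or still open speak of the compounds shown alone.

Measured compounds so far:
compound 1, `COc1ccc(C(=O)/C=C/c2cc3ccccc3[nH]c2=O)cc1`, 3390 nM
compound 2, `O=C(/C=C/c1cc2ccccc2[nH]c1=O)c1ccc(O)cc1`, 3040 nM

In a functional assay on MOLT-4 cells (Homo sapiens) for cytotoxicity, read by sulforhodamine B assay, with a stated time of 24 h (a higher number here means a weaker inhibitor of growth, a lower number a stronger inhibitor of growth), compound 2 gives 3040 nM, the lower of the two numbers, with compound 1 nearest at 3390 nM. The step of a 1.1-fold lower number from compound 1 to compound 2 (0.05 log units; within the scatter) lies within the scatter, so no order between these two compounds can be claimed.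

Compound 3, `O=C(/C=C/c1cc2ccccc2[nH]c1=O)c1ccc(Cl)cc1`, is not yet measured. It differs from compound 2 by chloro in place of hydroxy on an aromatic carbon. Among the compounds with values here, the only measured step, a 1.1-fold lower number from compound 1 to compound 2 (0.05 log units; within the scatter), touches the same oxygen but bears only loosely on this change, since here the oxygen leaves altogether and a chlorine enters. Within the data shown here, no measured pair shows hydroxy against chloro. On that basis no step beyond the scatter is expected in either direction, though the uncertainty is wide. Compound 3 is expected at 2500 nM, with a range from 800 nM to 8000 nM. This estimate means an expected step of a 1.2-fold lower number from compound 2 to compound 3 (0.08 log units; within the scatter).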

Compound 3, concentration for 50% growth inhibition: 3110 nM
The estimate for compound 3 lay 1.2-fold (0.09 log units) below the measured number; the range from low to high includes it.
By their numbers in this assay, from the lowest: compounds 2, 3 and 1 (each within the scatter of the next).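

In this assay the step of a 1.0-fold higher number from compound 2 to compound 3 (0.01 log units; within the scatter) lies within the scatter, so on an aromatic carbon para to a large group, 4-hydroxyphenyl and 4-chlorophenyl cannot be told apart, although hydroxy carries a hydrogen-bond donor and acceptor and chloro carries neither. The step of a 1.1-fold lower number from compound 1 to compound 3 (0.04 log units; within the scatter) is also within the scatter, so hydroxy, methoxy and chloro now stand on the shared core with no order among them. Nothing measured here speaks to why these three exchanges leave the number in the same place.

Still open, as far as these compounds go, is whether any group at this place separates from these three, for example an amine, a carboxylic acid or a longer alkoxy chain. The compounds shown also leave open whether the same holds at other carbons of this ring.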